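Furan-2-yl in place of methyl on a coumarin-like anilino core

The source may report more compounds than this note shows. Statements on the series, on what has been measured and on what is new or still open speak of the compounds shown alone.

Compound 1 `COc1ccc(Nc2cc(C)oc(=O)c2)cc1` was tested in a functional assay on SK-BR-3 cells (Homo sapiens) for cytotoxicity, read by MTT assay, with a stated time of 72 h; on this read-out higher numbers stand for an effect only at larger amounts of compound and lower numbers for an effect already at smaller amounts. In this assay compound 1 gives > 30 uM, which is a limit of the assay rather than a number (the limit of > 30 uM in this assay, at which 1 of the 3 values shown sits). Two further compounds that carry a ring at the same position have measured values: compound 2 `COc1ccc(Nc2cc(-c3ccc4ccccc4c3)oc(=O)c2)cc1` gives 0.13 uM, and compound 3 `Cc1ccc(Nc2cc(-c3ccccc3)oc(=O)c2)cc1` gives 0.09 uM; these two lie within the usual scatter of each other, so no order between them is claimed.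

Compound 4 `COc1ccc(Nc2cc(-c3ccco3)oc(=O)c2)cc1` differs from compound 1 by a single change: furan-2-yl in place of methyl on an aromatic carbon. No step between measured compounds that differ in exactly one place is available, so the size of this step must be judged from the compounds shown. Compound 2 and compound 3, each with a ring in that position, reach values far from the limit at which compound 1 sits, while the furan-2-yl ring of compound 4 is smaller than either of theirs. Compound 4 is therefore expected to move well beyond the scatter towards lower concentrations, with an expected step of an at least 30-fold lower number from compound 1 to compound 4 (1.47 log units; beyond the scatter). Compound 4 is estimated at 1 uM, within a range from 0.2 uM to 8 uM.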

Compound 4, concentration for half-maximal effect: 1.76 uM
For compound 4 the middle estimate is 1.8-fold (0.25 log units) below the measured one, and the stated range covers the measured number.
By their numbers in this assay, from the lowest: compounds 3 and 2 (each within the scatter of the next); then compound 4. At a limit, above all of these: compound 1.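

Among these compounds, the change from methyl to furan-2-yl, on an aromatic carbon next to the ring oxygen, gives the first step that can be read at this position: in this assay there is an at least 17-fold lower number from compound 1 to compound 4 (1.23 log units; beyond the scatter). The earlier compounds shown here offered no such pair, and this one shows that a five-membered aromatic ring with 1 hetero atom is enough to bring the core of compound 1 to a measurable value. The step can be stated only as a bound, because compound 1 stands at a limit of the assay: the limit of > 30 uM in this assay, at which 1 of the 4 values shown sits.

Whether the gain needs an aromatic ring at all stays open, since a longer chain such as butyl or a saturated ring such as cyclopentyl at this position is not among the compounds shown. Nor do they tell what the ring oxygen of furan-2-yl contributes, which a thiophene ring there would address.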